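Aryl methoxy to methylsulfanyl on the shared core

The source may hold more compounds than are shown below. What is called first, only, known or untested is meant among the compounds shown, and "the series" means these compounds.

Compound 1 `COc1ccc(CNc2nc(SC)nc3ccccc23)cc1` carries a substituted benzylamine on the core; compound 2 `CSc1nc(NCCCCCO)c2cccnc2n1` has a chain in its place, and compound 3 `COc1ccc(CNc2nc(S)nc3ccccc23)cc1` has hydrogen in place of methyl on the sulfur of the core. In a functional assay on HT-29 cells (Homo sapiens) for cytotoxicity, read by MTT assay, with a stated time of 72 h (a lower number here means a stronger inhibitor of growth, a higher number a weaker inhibitor of growth), compound 1 gives only a limit, > 100000 nM. Compound 2 also gives only a limit in this assay, > 100000 nM. Compound 3 gives 28600 nM in this assay. Going by the values given here, the single measured step, an at least 3.4-fold lower number from compound 1 to compound 3 (0.54 log units; beyond the scatter), concerns the sulfur of the core and is the only movement in the set, seen against (the limit of > 100000 nM in this assay, at which 2 of the 3 values shown sit).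

Compound 4 `CSc1ccc(CNc2nc(SC)nc3ccccc23)cc1` differs from compound 1 thus: methylsulfanyl in place of methoxy on an aromatic carbon. Among the compounds with values here, no measured step touches the aryl ring, and compound 4 keeps the methyl on the sulfur of the core that left compound 1 at the limit. The step from compound 1 to compound 3 therefore does not transfer. The expectation is no step beyond the scatter, with a limit the likeliest outcome. Compound 4 is expected at 100000 nM, between 30000 nM and 300000 nM. This amounts to an expected step of a number no higher from compound 1 to compound 4 (the limit leaves the size open).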

Compound 4, concentration for total growth inhibition: > 100000 nM
Compound 4 was reported as a limit (the forecaster's own chance of this, stated with the estimate: 75%); the middle value lies on the limit itself.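

In this assay compound 4 gives > 100000 nM, which is a limit. Going by these compounds alone, with compound 1 also at a limit, no step between compound 1 and compound 4 can be read: the limit of > 100000 nM in this assay, at which 3 of the 4 values shown sit.

As far as these compounds go, whether methylsulfanyl in place of methoxy on an aromatic carbon changes growth inhibition at all remains open.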